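The source may report more compounds than this note shows. Statements on the series, on what has been measured and on what is new or still open speak of the compounds shown alone.

Working notes on the series, all read in a functional assay on HeLa cells (Homo sapiens) for inhibition, read by sulforhodamine B assay; on this read-out higher numbers stand for weaker inhibition and lower numbers for stronger inhibition.

Compound 1 `Cc1ccc(NC2=CC(=O)c3nc4n(c3C2=O)[C@H]2OC[C@@H](O)[C@H]2OC4)cc1` gives 3860 nM in this assay. Compound 2 `O=C1C=C(Nc2ccccc2)C(=O)c2c1nc1n2[C@H]2OC[C@@H](O)[C@H]2OC1` gives 5620 nM. The two differ by hydrogen in place of methyl on an aromatic carbon, and the step of a 1.5-fold higher number from compound 1 to compound 2 (0.16 log units; within the scatter) says nothing beyond the scatter. Compound 3 `O=C1C=C(NC2CCCC2)C(=O)c2c1nc1n2[C@H]2OC[C@@H](O)[C@H]2OC1` returns only a limit, > 16000 nM, not a number. Of the three values shown, compound 3 alone sits at the limit of > 16000 nM in this assay, at which 1 of the 3 values shown sits; on the numbers shown it stands at the weak end of the set. The two steps that reach it are an at least 4.1-fold higher number from compound 1 to compound 3 (0.61 log units; beyond the scatter) and an at least 2.8-fold higher number from compound 2 to compound 3 (0.45 log units; beyond the scatter), both beyond the scatter, so swapping an aryl group for cyclopentyl on the amine nitrogen has twice cost potency.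

Compound 4 `CCCc1ccc(NC2=CC(=O)c3nc4n(c3C2=O)[C@H]2OC[C@@H](O)[C@H]2OC4)cc1` differs from compound 3 by 4-propylphenyl in place of cyclopentyl on an amine nitrogen. This runs the aryl-to-cyclopentyl steps backwards, so a move in this assay toward stronger inhibition, at least modest in size, is expected, with compound 4 landing near compound 1 and compound 2. The step expected is an at least 5.0-fold lower number from compound 3 to compound 4 (0.69 log units; beyond the scatter). For compound 4 the estimate in this assay is 3200 nM, within 1200 nM to 8500 nM.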

Compound 4, half-maximal inhibitory concentration: 4990 nM
Compound 4: middle estimate off by 1.6-fold (0.19 log units), on the low side; measured number inside the range.
By their numbers in this assay, from the lowest: compounds 1, 4 and 2 (each within the scatter of the next). At a limit, above all of these: compound 3.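

In this assay, the step of an at least 3.2-fold lower number from compound 3 to compound 4 (0.50 log units; beyond the scatter) gives a third comparison between an aryl group and cyclopentyl on the amine nitrogen, and all three lie beyond the scatter, with no compound shown going against that pattern. The new information lies in the aromatic ring: propyl in place of hydrogen gives a 1.1-fold lower number from compound 2 to compound 4 (0.05 log units; within the scatter), and lengthening the methyl of compound 1 to the propyl of compound 4 gives a 1.3-fold higher number from compound 1 to compound 4 (0.11 log units; within the scatter), so both steps lie within the scatter and hydrogen, methyl and propyl on that aromatic carbon are not told apart in this read-out. The size of the loss on going to cyclopentyl stays bounded on one side only, since compound 3 still returns a limit and not a number: the limit of > 16000 nM in this assay, at which 1 of the 4 values shown sits.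

From the compounds shown here alone, whether a group of another kind on the same aromatic carbon, such as an amine, a carboxylic acid or a methoxy group, would also leave the number within the scatter stays open. So does whether the loss belongs to cyclopentyl alone or extends to other groups on the amine nitrogen, such as cyclohexyl, benzyl or a straight alkyl chain.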